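The source may report more compounds than this note shows. Statements on the series, on what has been measured and on what is new or still open speak of the compounds shown alone.

Measured compounds and their values in a physicochemical assay for lipophilicity, read by HPLC, measured as chromatographic lipophilicity, at pH 7.4; on this read-out lower numbers stand for lower lipophilicity and higher numbers for higher lipophilicity:

Compound 1 `CCCCCCCC(=O)NCCCN(C)[C@H]1C[C@@H](C)O[C@@H](O[C@@H]2[C@@H](C)[C@H](O[C@H]3C[C@@](C)(OC)[C@@H](O)[C@H](C)O3)[C@@H](C)C(=O)O[C@H](CC)[C@@](C)(O)[C@H](O)[C@@H](C)C(=O)[C@H](C)C[C@@]2(C)OC)[C@@H]1O` gives 6.44 in this assay.
Compound 2 `CCCCCCCC(=O)NCCCN(C)[C@H]1C[C@@H](C)O[C@@H](O[C@@H]2[C@@H](C)[C@H](O[C@H]3C[C@@](C)(OC)[C@@H](O)[C@H](C)O3)[C@@H](C)C(=O)O[C@H](CC)[C@@](C)(O)[C@H](O)[C@@H](C)N(C)C[C@H](C)C[C@@]2(C)O)[C@@H]1O` gives 3.74 in this assay.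
Compound 3 `CC[C@H]1OC(=O)[C@H](C)[C@@H](O[C@H]2C[C@@](C)(OC)[C@@H](O)[C@H](C)O2)[C@H](C)[C@@H](O[C@@H]2O[C@H](C)C[C@H](N(C)CCCNC(C)=O)[C@H]2O)[C@](C)(O)C[C@@H](C)CN(C)[C@H](C)[C@@H](O)[C@]1(C)O` gives 2.06 in this assay.

Compound 1 stands highest of the three, and its gap to compound 2 and to compound 3 is beyond the scatter in each case. Compound 1 and compound 2 share the same side chain but differ in their cores; the difference between the two cores is not broken down here.

Compound 2 and compound 3 differ in one place only. The change is hydrogen in place of hexyl on a saturated chain carbon bound to a carbonyl carbon and it made the step of a number 1.68 log units lower from compound 2 to compound 3 (beyond the scatter) in this assay, a large drop that is well beyond the scatter.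

Compound 4 `CC[C@H]1OC(=O)[C@H](C)[C@@H](O[C@H]2C[C@@](C)(OC)[C@@H](O)[C@H](C)O2)[C@H](C)[C@@H](O[C@@H]2O[C@H](C)C[C@H](N(C)CCCNC(C)=O)[C@H]2O)[C@](C)(OC)C[C@@H](C)C(=O)[C@H](C)[C@@H](O)[C@]1(C)O` has not yet been measured. It differs from compound 1 by hydrogen in place of hexyl on a saturated chain carbon bound to a carbonyl carbon. The place of this change is described in exactly the same words as the place of the change from compound 2 to compound 3, so it is the same change, made on the core of compound 1 instead of the core of compound 2. Among the measured compounds this change occurs only once, where it made the step of a number 1.68 log units lower from compound 2 to compound 3 (beyond the scatter) in this assay. The same change is therefore expected to give a step of about the same size here, namely a number 1.69 log units lower from compound 1 to compound 4 (beyond the scatter). On that basis compound 4 is estimated to give 4.75 in this assay, expected to lie between 4.15 and 5.35.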

Compound 4, distribution coefficient: 3.08
Compound 4: the middle estimate sits 1.67 log units above what was measured, and the stated range ends above it.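

In this assay, putting hydrogen in place of hexyl on a saturated chain carbon bound to a carbonyl carbon gives a number 3.36 log units lower from compound 1 to compound 4 (beyond the scatter) on one core and a number 1.68 log units lower from compound 2 to compound 3 (beyond the scatter) on the other, so the same edit has now been seen on two different cores. These two pairs show that the direction of the step carried over from one core to the other while its size did not, the step on the core of compound 1 being the larger one, so a step measured on one core was a poor guide to the exact size of the step on the other, and two pairs cannot show how the change would behave on any further core. Nothing available explains why the same change counts for more on one core than on the other.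

The compounds shown leave open whether a shorter chain such as propyl, put in the place of hexyl, would give a step part of the way towards that of hydrogen on each core. They also leave open whether a group of another kind there, such as an amine or a carboxylic acid, would differ between the two cores in the same way.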